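Methoxy removal on two cores, cytotoxicity at one concentration

The compounds below may be only part of what the source reports. "The series", "measured", "known", "first", "only" and "open" are said of these compounds alone.

Compound 1 `COc1ccc(-c2cc(/C=C/C(=O)c3ccc(N)cc3)[nH]n2)cc1` and compound 2 `COc1ccc(-c2cc(/C=C/C(=O)c3ccc(N)cc3)[nH]n2)cc1OC` share one core; compound 1 differs from compound 2 by hydrogen in place of methoxy on an aromatic carbon. In a functional assay on NCI-H460 cells (Homo sapiens) for cytotoxicity, read by sulforhodamine B assay, with a stated time of 48 h, tested at 0.1 uM (on this read-out higher numbers stand for a weaker effect at the one concentration tested and lower numbers for a stronger effect), compound 2 gives 100% and compound 1 gives 102%, so the step is a number 2 percentage points higher from compound 2 to compound 1 (within the scatter). Compound 3 `COc1cc(C(=O)/C=C/c2cc(-c3cc(OC)c(OC)c(OC)c3)n[nH]2)cc(OC)c1OC` carries another core; the difference between the two cores is not broken down here. In this assay, among the compounds with values here, compound 3 gives 104%, a number within the scatter of compound 1 and of compound 2 alike, so at this concentration no compound stands apart from the others.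

Compound 4 `COc1ccc(-c2cc(/C=C/C(=O)c3cc(OC)c(OC)c(OC)c3)[nH]n2)cc1OC` has not yet been measured. It differs from compound 3 by hydrogen in place of methoxy on an aromatic carbon. Within the data shown here, this is the same kind of change as the one from compound 2 to compound 1, but the place is not identical: here it is also meta to a methoxy group, which does not hold in the earlier pair. The step from compound 3 to compound 4 in this assay is expected to be a number 2 percentage points lower from compound 3 to compound 4 (within the scatter), resting on the earlier step of a number 2 percentage points higher from compound 2 to compound 1 (within the scatter) and on the closeness of all three measured numbers. Compound 4 is therefore estimated at 102%, with a range from 94% to 110%.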

Compound 4, a percentage reported as activity, at one concentration (the size of the read-out at that concentration, not a potency): 100%
Beside the measured number, compound 4's estimate is 2 percentage points above it; low and high end bracket the measured number.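

In this assay, hydrogen in place of methoxy on an aromatic carbon comes out as a number 4 percentage points lower from compound 3 to compound 4 (within the scatter), and the two steps for this change do not differ: the same change on two cores in this assay, a number 2 percentage points higher (within the scatter) from compound 2 to compound 1 and a number 4 percentage points lower (within the scatter) from compound 3 to compound 4, 6 percentage points apart, within the scatter of two such steps

On both cores, then, the change leaves the read-out within the scatter at the one concentration tested, and the two cores give no sign of treating it differently. This does not show that the step has a shared size or direction, since neither step stands clear of the scatter, the two places on the ring are not identical, and a single-concentration percentage is not a potency.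

The compounds shown leave open how the change would read at a concentration where the read-out moves clearly away from these numbers. Also open, going by these compounds, is how other groups on the same aromatic carbon, such as a hydroxyl, a chlorine atom or a carboxylic acid, would read in this assay on either core.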